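A few compounds are considered here, and "the series" means these few. Any claim that something is new, unique, unknown or untested is made for them only; others in the source may bear on it.

Compound 1, with the structure `CNC(=O)c1ccc(Sc2ccc(NC(=S)Nc3ccc(OC(F)(F)F)cc3)cc2)nc1`, and compound 2, with the structure `CNC(=O)c1ccc(Sc2cccc(NC(=S)Nc3ccc(F)c(Cl)c3)c2)nc1`, share one core and differ in the aryl group carried on the thiourea. In a functional assay on B16-BL6 cells (Mus musculus) for cytotoxicity, read by MTT assay, with a stated time of 48 h (on this read-out higher numbers stand for weaker inhibition and lower numbers for stronger inhibition), compound 1 gives > 100000 nM, which is a limit of the assay and not a number. In this assay compound 2 gives > 100000 nM, again a limit rather than a measured number. Compound 2 therefore stands at the edge of what the assay reports, a position summed up by the limit of > 100000 nM in this assay, at which 2 of the 2 values shown sit, and nothing in the data places it above or below compound 1.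

Compound 3, with the structure `CNC(=O)c1ccc(Sc2cccc(NC(=S)Nc3ccc(Cl)cc3)c2)nc1`, is the next compound to be examined. Its change from compound 2 is 4-chlorophenyl in place of 3-chloro-4-fluorophenyl on an amide-type nitrogen. Among the compounds with values here, no measured step between two compounds is available here, so the expectation for compound 3 rests on the two limits alone. Compound 3 is expected to remain at the limit of this assay as well, with an estimated value of 150000 nM and a range from 60000 nM to 500000 nM. This estimate implies a step that the limit leaves unreadable from compound 2 to compound 3, which is expected to be no more than the scatter.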

Compound 3, half-maximal inhibitory concentration: 67500 nM
Compound 3: middle estimate off by 2.2-fold (0.35 log units), on the high side, and the stated range covers the measured number.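

In this assay compound 3 gives 67500 nM, the first value among the compounds shown that is a measured number and not a limit, so the aryl group on this amide-type nitrogen can now be read on the scale of the assay. Replacing 3-chloro-4-fluorophenyl with 4-chlorophenyl gives an at least 1.4-fold lower number from compound 2 to compound 3 (0.17 log units; that floor lies within the scatter), and since this is only a floor, the true size of the step cannot be told from it. The change therefore shows that a 4-chlorophenyl compound can give a number inside the reported range, but most of the values shown still rest at the edge of the assay: the limit of > 100000 nM in this assay, at which 2 of the 3 values shown sit.

From the compounds shown here alone, it remains open how far the number in this assay would move with a methoxy group, an amine or a longer alkyl chain in place of the chlorine on the 4-chlorophenyl group of compound 3. Going by these compounds, it is also open what a carbonyl in place of the thiocarbonyl, or a carboxylic acid in place of the methyl amide on the shared core, would do to that number.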